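Carbamate aryl swap: indanyl for methoxyphenyl

The source may hold more compounds than are shown below. What is called first, only, known or untested is meant among the compounds shown, and "the series" means these compounds.

Working notes on the sulfonyl hydrazide carbamate series. Compound 1 `COc1ccc(OC(=O)N(Nc2ccccc2)S(=O)(=O)c2ccccc2)cc1` gives 584 nM in a functional assay on RAW264.7 cells (Mus musculus), read by immunoassay, with a stated time of 24 h; a lower number here means a stronger inhibitor, a higher number a weaker inhibitor. Compound 2 `COc1ccc(S(=O)(=O)N(Nc2ccccc2)C(=O)Oc2ccccc2)cc1` gives 4430 nM. Compound 3 `COc1ccc(OC(=O)N(Nc2ccccc2)S(=O)(=O)c2ccc(OC)cc2)cc1` gives 490 nM and so shows the lowest number of the three, though compound 1 lies within the scatter of it, the gap being a 1.2-fold lower number from compound 1 to compound 3 (0.08 log units; within the scatter). Compound 2 is further off: a 9.0-fold lower number from compound 2 to compound 3 (0.96 log units; beyond the scatter).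

Compound 4 `COc1ccc(S(=O)(=O)N(Nc2ccccc2)C(=O)Oc2ccc3c(c2)CCC3)cc1` is the next step: 2,3-dihydro-1H-inden-5-yl in place of 4-methoxyphenyl on an oxygen next to a carbonyl group. Within the data shown here, the step that bears on it is the one from compound 2 to compound 3, which adds the methoxy of the 4-methoxyphenyl group that now leaves, with a 9.0-fold lower number from compound 2 to compound 3 (0.96 log units; beyond the scatter). The step of a 1.2-fold lower number from compound 1 to compound 3 (0.08 log units; within the scatter) concerns the other aryl group and is within the scatter. Among the measured compounds shown here, compound 4 loses that methoxy but gains a fused five-membered non-aromatic ring in its place, for which no measured precedent exists here. A weaker inhibitor than compound 3 is therefore expected, but not as weak as compound 2. Compound 4 is estimated at 1300 nM in this assay, range 450 nM to 4000 nM, the expected step being a 2.7-fold higher number from compound 3 to compound 4 (0.42 log units; beyond the scatter).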

Compound 4, half-maximal inhibitory concentration: 4.5 nM
Estimate against measurement, compound 4: 290-fold (2.46 log units) above; the whole stated range lies above it.
By their numbers in this assay, from the lowest: compound 4; then compounds 3 and 1 (each within the scatter of the next); then compound 2.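

The aryl group on an oxygen next to a carbonyl group proves far more sensitive than compounds 1 to 3 suggested: in this assay the change gives a 110-fold lower number from compound 3 to compound 4 (2.04 log units; beyond the scatter), and against the unsubstituted phenyl it gives a 980-fold lower number from compound 2 to compound 4 (2.99 log units; beyond the scatter). Adding the methoxy gave only a 9.0-fold lower number from compound 2 to compound 3 (0.96 log units; beyond the scatter), and compound 4 carries no methoxy at all, so a methoxy is not required at this position for a low number. No supporting measurement accounts for the size of this step.

The compounds shown do not separate the fused five-membered ring from simple alkyl substitution, which a 3,4-dimethylphenyl or 4-ethylphenyl carbamate would test. From the compounds shown here alone, it also remains open whether the 2,3-dihydro-1H-inden-5-yl gain persists with an unsubstituted phenyl on the sulfonyl group.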